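Dropping the Ethyl Ester: What to Expect for the Acid

The source may hold more compounds than are shown below. What is called first, only, known or untested is meant among the compounds shown, and "the series" means these compounds.

Among the compounds with values here, compound 1 `CCOC(=O)/C=C/c1ccccc1OCc1nc(C)c(C)nc1C` carries an ethyl ester on a cinnamate side chain, and in a functional assay on a cell-free system (Platelet, plasma, Oryctolagus cuniculus) for inhibition, with a stated time of 5 min (on this read-out lower numbers stand for stronger inhibition and higher numbers for weaker inhibition), compound 1 gives 502000 nM, the only actual number among the three measured compounds. Compound 2 `CCOC(=O)/C=C/c1cccc(OC)c1OCc1nc(C)c(C)nc1C` reaches only the limit of this assay, > 2000000 nM. Compound 3 `CCOC(=O)/C=C/c1cc(Cl)ccc1OCc1nc(C)c(C)nc1C` likewise stops at a limit, > 2000000 nM. Both ring additions weakened inhibition: an at least 3.9-fold higher number from compound 1 to compound 2 (0.60 log units; beyond the scatter) and an at least 3.9-fold higher number from compound 1 to compound 3 (0.60 log units; beyond the scatter), each described as at least modest since the limit of > 2000000 nM in this assay, at which 2 of the 3 values shown sit, hides their true size. Compound 4 `Cc1nc(C)c(COc2ccccc2/C=C/C(=O)O)nc1C` changes a different place: hydrogen in place of ethyl on an oxygen next to a carbonyl group. Neither measured step touches the ester, so no direct guide exists; the expectation is a step of about a 1.0-fold lower number from compound 1 to compound 4 (0.00 log units; within the scatter), within the scatter. Compound 4 is therefore estimated at 500000 nM, between 100000 nM and 2000000 nM.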

Compound 4, half-maximal inhibitory concentration: 54000 nM
Beside the measured number, compound 4's estimate is 9.3-fold (0.97 log units) above it, and the stated range ends above it.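

In this assay, the ester end of the side chain proves to be a place where a small change counts: hydrogen in place of ethyl, which turns ethoxycarbonyl into carboxy, gives a 9.3-fold lower number from compound 1 to compound 4 (0.97 log units; beyond the scatter) and so stronger inhibition. The earlier steps, both additions to the ring, only weakened inhibition, so this is the first change shown that improves on compound 1. Nothing measured here explains this gain.

On these data alone, what a methyl ester or a primary amide would give at this place stays open. So does whether methoxy or chloro would also weaken inhibition on compound 4.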